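Ethynyl for Vinyl: One Change on Two Cores

The source may hold more compounds than are shown below. What is called first, only, known or untested is meant among the compounds shown, and "the series" means these compounds.

Measured so far:
compound 1 `C=Cc1nc2ccccc2s1` gives > 40000 nM in a functional assay on NCI-H522 cells (Homo sapiens) for cytotoxicity, with a stated time of 3 days; on this read-out lower numbers stand for stronger inhibition and higher numbers for weaker inhibition
compound 2 `C#Cc1nc2ccccc2s1` gives 860 nM
compound 3 `C=Cc1nc(C(=O)OCC)cs1` gives > 40000 nM

The value for compound 1 is a limit of the assay, not a number. The value for compound 3 is likewise a limit of the assay. Together they make up (the limit of > 40000 nM in this assay, at which 2 of the 3 values shown sit).

Within the core of compound 1, the change ethynyl in place of vinyl on an aromatic carbon produced an at least 46-fold lower number from compound 1 to compound 2 (1.66 log units; beyond the scatter). Compound 2 is the only one of the three with a numerical value.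

Compound 4 `C#Cc1nc(C(=O)OCC)cs1` has not yet been measured. It differs from compound 3 by ethynyl in place of vinyl on an aromatic carbon. For the measured compounds named here, this is the same kind of change as the one from compound 1 to compound 2, but the surroundings differ: in the core of compound 1 the aromatic carbon sits in a ring that is part of a fused or bridged system of two rings, whereas in the core of compound 3 it sits two ring bonds from the ring atom that bears a group of 5 heavy atoms. How the two cores differ beyond that is not broken down here.

Going by the values given here, since compound 3 stands at a limit, only the step from compound 1 to compound 2 gives a footing for the size of the step to compound 4. Resting on an at least 46-fold lower number from compound 1 to compound 2 (1.66 log units; beyond the scatter), the step is expected to be an at least 6.6-fold lower number from compound 3 to compound 4 (0.82 log units; beyond the scatter), though the changed surroundings make a smaller move likely and leave a fair chance that only a limit is reported again. Compound 4 is estimated at 6000 nM, within 900 nM to 40000 nM.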

Compound 4, half-maximal inhibitory concentration: 2670 nM
Compound 4: the middle estimate sits 2.2-fold (0.35 log units) above what was measured; low and high end bracket the measured number.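

On the second core, in this assay, ethynyl in place of vinyl on an aromatic carbon again brought a large move, with an at least 14-fold lower number from compound 3 to compound 4 (1.17 log units; beyond the scatter). The vinyl compounds, compound 1 and compound 3, give no number on either core, only a limit of the assay: the limit of > 40000 nM in this assay, at which 2 of the 4 values shown sit. The direction of the change therefore carried from one core to the other in both cases shown, but the true size of neither step is known, and nothing can be said about whether the core alters that size: the same change on two cores in this assay, an at least 46-fold lower number (1.66 log units; beyond the scatter) from compound 1 to compound 2 and an at least 14-fold lower number (1.17 log units; beyond the scatter) from compound 3 to compound 4; the limit leaves it open whether they differ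

The compounds shown leave open whether the same move would appear with something other than the group of 5 heavy atoms on the core of compound 3, such as a carboxylic acid or an amine in its place. They also leave open how much depends on the ethynyl group itself, since neither a saturated ethyl group, a nitrile nor a longer alkyne chain stands beside it on either core, and two pairs on two cores are too few to call the change general across the series.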